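The source may report more compounds than this note shows. Statements on the series, on what has been measured and on what is new or still open speak of the compounds shown alone.

Working notes on the series. Compound 1 `Cc1ccc2[nH]c(=O)c(-c3nc4cc([N+](=O)[O-])ccc4[nH]3)cc2c1` is the point of departure. In a functional assay on BEL-7404 cells for cytotoxicity against BEL-7404 tumor cell line (Homo sapiens), read by MTT assay, with a stated time of 48 h (on this read-out lower numbers stand for stronger inhibition and higher numbers for weaker inhibition), compound 1 gives > 100000 nM, which is a limit of the assay and not a number. Compound 2 `Cc1ccc2[nH]c(=O)c(-c3nc4ccccc4[nH]3)cc2c1` shares the core and carries hydrogen in place of nitro on an aromatic carbon; in this assay compound 2 gives > 100000 nM, again a limit rather than a number. Compound 3 `Cc1ccc2[nH]c(=O)c(-c3nc4cc(Cl)ccc4[nH]3)cc2c1` carries chloro in place of nitro on that aromatic carbon; in this assay compound 3 gives 39000 nM. The step of an at least 2.5-fold lower number from compound 1 to compound 3 (0.40 log units; beyond the scatter) and the step of an at least 2.5-fold lower number from compound 2 to compound 3 (0.40 log units; beyond the scatter) both concern the substituent on that ring, while the step that the two limits leave unreadable from compound 1 to compound 2 cannot be sized because both values sit at the limit of > 100000 nM in this assay, at which 2 of the 3 values shown sit. For the measured compounds named here, compound 1 thus stands at the limit of the assay, as does compound 2, with compound 3 the only numbered value in the set.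

Compound 4 `COc1ccc2[nH]c(=O)c(-c3nc4cc([N+](=O)[O-])ccc4[nH]3)cc2c1` is not yet measured. It differs from compound 1 by methoxy in place of methyl on an aromatic carbon. Going by the values given here, none of the measured steps touches this part of the core; all three concern the other ring, so no measured step bears directly on the change, and its size cannot be read from the series. Nothing in the data suggests movement, and the step of a number no higher from compound 1 to compound 4 (the limit leaves the size open) is expected to stay within the scatter. In this assay compound 4 is therefore estimated at 100000 nM, with a range from 30000 nM to 300000 nM, and is likely to be reported again only as a limit.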

Compound 4, half-maximal inhibitory concentration: > 100000 nM
Compound 4 was reported as a limit; the forecaster's own chance of this, stated with the estimate: 70%; the middle value sits exactly at the limit.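

In this assay compound 4 gives > 100000 nM, a limit and not a number. Compound 1 also stands at a limit, so no new step can be read between compound 1 and compound 4: the limit of > 100000 nM in this assay, at which 3 of the 4 values shown sit. The compounds shown leave open what methoxy in place of methyl does to a value that is a number rather than a limit.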